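Adding a Methoxy Group to Compound 2

The source may report more compounds than this note shows. Statements on the series, on what has been measured and on what is new or still open speak of the compounds shown alone.

In a functional assay on HepG2 cells (Homo sapiens) for cytotoxicity, read by MTT assay, with a stated time of 48 h (on this read-out higher numbers stand for weaker inhibition and lower numbers for stronger inhibition), compound 2 `CN1CCC(NC(=O)c2ccc(Nc3ncc(Cl)c(NC4CCCC4)n3)cc2)CC1` gives 2200 nM, the lowest of the two numbers recorded so far. Compound 1 `COc1cc(C(=O)NC2CCN(C)CC2)ccc1Nc1ncc(Br)c(NC2CCCC2)n1` gives 4900 nM in this assay, a higher number that lies beyond the usual scatter. Compound 3 `COc1cc(C(=O)NC2CCN(C)CC2)ccc1Nc1ncc(Cl)c(NC2CCCC2)n1` is compound 2 with one change: methoxy in place of hydrogen on an aromatic carbon. Going by the values given here, no measured pair shows this exact change alone, so the step from compound 2 to compound 3 in this assay is expected to be modest, most likely toward a higher number, close to the range of scatter. Compound 3 is therefore estimated at 3500 nM, within 1500 nM to 9000 nM, giving an expected step of a 1.6-fold higher number from compound 2 to compound 3 (0.20 log units; within the scatter).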

Compound 3, half-maximal inhibitory concentration: 9300 nM
Compound 3: middle estimate off by 2.7-fold (0.42 log units), on the low side; measured number outside the range, above it.
By their numbers in this assay, from the lowest: compound 2; then compounds 1 and 3 (each within the scatter of the next).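

Methoxy in place of hydrogen on this aromatic carbon, ortho to a large group, gives a 4.2-fold higher number from compound 2 to compound 3 (0.63 log units; beyond the scatter) in this assay and so weaker inhibition, the first direct reading of this change. With methoxy present, chloro in place of bromo gives a 1.9-fold higher number from compound 1 to compound 3 (0.28 log units; within the scatter) and so does not clearly separate these two halogens here. Nothing measured explains why methoxy has this effect.

Still open, from the compounds shown here alone, is whether the step is specific to methoxy. A hydroxyl, an ethoxy or an amine on the same carbon would help to show this.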